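Working notes: phenyl to 2,4-dichlorophenyl, compound 1 to compound 3

The compounds below may be only part of what the source reports. "The series", "measured", "known", "first", "only" and "open" are said of these compounds alone.

Measured in a functional assay on SK-MEL-28 cells (Homo sapiens) for inhibition, read by sulforhodamine B assay, with a stated time of 48 h (a higher number here means a weaker inhibitor of growth, a lower number a stronger inhibitor of growth), so far:
- compound 1 `O=C(Cc1csc2nc(-c3ccc(Br)cc3)cn12)N/N=C/c1ccccc1` with > 100000 nM as a limit
- compound 2 `COc1cccc(OC)c1/C=N/NC(=O)Cc1csc2nc(-c3ccc(Br)cc3)cn12` with > 100000 nM as a limit

Compound 1 gives > 100000 nM in this assay and this is a limit, not a number. Compound 2 gives > 100000 nM and this too is a limit. Going by the values given here, the series so far offers only the limit of > 100000 nM in this assay, at which 2 of the 2 values shown sit, as its reference point.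

The next entry is compound 3 `O=C(Cc1csc2nc(-c3ccc(Br)cc3)cn12)N/N=C/c1ccc(Cl)cc1Cl` and the change reads 2,4-dichlorophenyl in place of phenyl on a carbon with a double bond to nitrogen with 2,4-dichlorophenyl in place of phenyl on a carbon with a double bond to nitrogen. Among the compounds with values here, the only measured step at this place is a step that the two limits leave unreadable from compound 1 to compound 2 and it gives no size to carry over. Within the data shown here, no measured step supports a large shift, so the expectation stays close to the limit, with any reported number lying on the stronger side. The expected change is an at least 1.4-fold lower number from compound 1 to compound 3 (0.15 log units; that floor lies within the scatter) and it remains tentative. In this assay the estimate for compound 3 is 70000 nM with an expected range from 25000 nM to 100000 nM and a real chance of another limit.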

Compound 3, concentration for total growth inhibition: > 100000 nM
Compound 3 was reported as a limit; the forecaster's own chance of this, stated with the estimate: 65%; middle value at least 1.4-fold (0.15 log units) from the limit.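

No new step can be read from compound 3 against compound 1 or compound 2, as all three give only a limit in this assay and share one reference point: the limit of > 100000 nM in this assay, at which 3 of the 3 values shown sit.

As far as these compounds go, whether any group on the carbon with a double bond to nitrogen can bring a readable number on this core remains open.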